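Adding a cinnamoyl-type ester to an alcohol

This account rests on a few compounds, and the source may have more. Where it says the series, first, only, none or still open, it means among the compounds named here.

Compound 1 `O=C(/C=C/c1ccccc1)OC1CC2(N3CCCC3)CC(c3ccccc3)C1C(c1ccccc1)C2` gives 3500 nM
Compound 2 `OC1CC2(N3CCCCC3)CC(c3ccccc3)C1C(c1ccccc1)C2` gives 37300 nM

In an ADME assay on L6 cells (Rattus norvegicus) for cytotoxicity, with a stated time of 72 h (a lower number here means a stronger inhibitor, a higher number a weaker inhibitor), compound 2 stands highest of the two at 37300 nM, and the gap to compound 1 lies beyond the usual scatter. Compound 3 `O=C(/C=C/c1ccccc1)OC1CC2(N3CCCCC3)CC(c3ccccc3)C1C(c1ccccc1)C2` changes compound 2 in one place: (2-phenylethenyl)carbonyl in place of hydrogen on an oxygen on a saturated carbon puts (2-phenylethenyl)carbonyl in place of hydrogen on an oxygen on a saturated carbon. Compound 1 already carries that group and gives 3500 nM in this assay, so a clearly lower number, beyond the scatter, is expected. The estimated change is a 9.3-fold lower number from compound 2 to compound 3 (0.97 log units; beyond the scatter) in size. For compound 3 the expected value is 4000 nM, with an estimated range of 1500 nM to 11000 nM.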

Compound 3, half-maximal inhibitory concentration: 10500 nM
Compound 3: middle estimate off by 2.6-fold (0.42 log units), on the low side; low and high end bracket the measured number.
By their numbers in this assay, from the lowest: compound 1; then compound 3; then compound 2.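

In this assay, hydroxy to ((2-phenylethenyl)carbonyl)oxy gives a 3.6-fold lower number from compound 2 to compound 3 (0.55 log units; beyond the scatter) with piperidin-1-yl held constant, so the ester lowers the number without any change at the amine. With the ester held constant, piperidin-1-yl in place of pyrrolidin-1-yl on a saturated ring carbon gives a 3.0-fold higher number from compound 1 to compound 3 (0.48 log units; beyond the scatter) and shows that the amine matters too. No measured evidence here explains either step. The compounds shown leave open whether a plain acetyl ester on that oxygen would lower the number as far as this one. They also leave open where a dimethylamino group at the amine place would fall.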